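Adding a Phenyl Group to a Pyrazoline Ring

The source may report more compounds than this note shows. Statements on the series, on what has been measured and on what is new or still open speak of the compounds shown alone.

Measured compounds and their values in a functional assay on the whole organism (strain Charles Foster albino) for inhibition, with Rattus norvegicus as the target, read by paw edema, with stated times of 30 min and 3 h, at a dose of 50 mg/kg by the oral route; on this read-out lower numbers stand for less inhibition and higher numbers for more inhibition at the one dose given (going by the name of the read-out):
- compound 1, `CN(C)c1ccc(C2CC(c3ccncc3)=NN2)cc1`: 0%
- compound 2, `COc1ccc(OC)c(C2CC(c3ccncc3)=NN2)c1`: 13%

Two compounds share a five-membered ring bearing a pyridin-4-yl group and differ only in the aryl group attached to the other carbon of that ring. In this assay compound 1 gives 0%, no measurable effect on paw swelling at the dose tested. Compound 2, carrying two methoxy groups on its aryl ring, gives 13% in this assay. Compound 2 therefore stands highest of the two numbers, and its gap to compound 1 lies beyond the usual scatter of such measurements, though the effect itself is still small.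

Compound 3, `COc1ccc(OC)c(C2CC(c3ccncc3)=NN2c2ccccc2)c1`, has not yet been measured. It differs from compound 2 in one place: phenyl in place of hydrogen on an amine nitrogen in a ring. The new group sits on the amine nitrogen of the five-membered non-aromatic ring, next to the ring nitrogen.

Within the data shown here, no measured pair shows what this particular change does, so the direction of the step can only be guessed from the weak starting point of compound 2. A moderate rise is expected, and the step of a number 12 percentage points higher from compound 2 to compound 3 (beyond the scatter) is estimated to stay within a modest range. Compound 3 is expected to give about 25% in this assay, with a likely range from 5% to 50%.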

Compound 3, a percentage reported as inhibition, in the whole organism at one dose (the size of the read-out at that dose, not a potency): 18%
The estimate for compound 3 lay 7 percentage points above the measured number; the measured number falls inside the stated range.
By their numbers in this assay, from the lowest: compound 1; then compounds 2 and 3 (each within the scatter of the next).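

Among these compounds, this is the first look at the amine nitrogen of the five-membered non-aromatic ring. In this assay, phenyl in place of hydrogen at this nitrogen gives a number 5 percentage points higher from compound 2 to compound 3 (within the scatter) and so the two compounds cannot be told apart on this read-out, which means that a group of 6 heavy atoms, forming one six-membered aromatic ring of carbon only, can sit here with neither a loss nor a gain in inhibition beyond ordinary variation between repeated measurements. Nothing measured here explains why the phenyl group leaves the number within the scatter.

On these data alone, it remains open whether a smaller or more different group on this nitrogen, such as methyl, acetyl or a short chain ending in a carboxylic acid, would move the inhibition clearly in either direction at this one dose. As far as these compounds go, it is equally open whether phenyl at this nitrogen would behave the same way on the core of compound 1, which carries a dimethylamino group on its aryl ring in place of the two methoxy groups.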